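Bromo to fluoro on an inactive pyridazinone series

The source may report more compounds than this note shows. Statements on the series, on what has been measured and on what is new or still open speak of the compounds shown alone.

Compound 1, `COc1cccc(Cc2ccnn(CC(=O)Nc3ccc(Br)cc3)c2=O)c1`, gives > 50000 nM in a functional assay on HL-60 cells (Homo sapiens), read by calcium flux (on this read-out higher numbers stand for an effect only at larger amounts of compound and lower numbers for an effect already at smaller amounts), a limit of the assay.
Compound 2, `COc1ccc(Cc2cc(-c3ccc(C)cc3)nn(CC(=O)Nc3ccc(Br)cc3)c2=O)cc1`, gives > 50000 nM in this assay, again a limit.
Compound 3, `Cc1cc(Cc2ccccc2)c(=O)n(CC(=O)Nc2ccc(Br)cc2)n1`, gives > 50000 nM in this assay, also a limit.

Compound 3 stands where every measured compound stands: at the limit of this assay. Within the data shown here, of the three values shown, all sit at that limit (the limit of > 50000 nM in this assay, at which 3 of the 3 values shown sit), so no step between measured compounds can be sized, and no order among compounds 1, 2 and 3 can be read from the numbers.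

Compound 4, `Cc1cc(Cc2ccccc2)c(=O)n(CC(=O)Nc2ccc(F)cc2)n1`, differs from compound 3 in one place: fluoro in place of bromo on an aromatic carbon. Nothing measured shows what a change of this kind does in this assay, since every compound shown returns only a limit. The change is small, and the step from compound 3 to compound 4 is expected to be none beyond the scatter, a step that the limit leaves unreadable from compound 3 to compound 4, with the most likely outcome that compound 4 also returns only a limit. Compound 4 is estimated at 100000 nM, within a range from 20000 nM to 500000 nM.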

Compound 4, half-maximal effective concentration: > 50000 nM
Compound 4: no number, only a limit (the forecaster's own chance of this, stated with the estimate: 85%); the middle value is on the limit's open side.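

Among these compounds, compound 3 and compound 4 both return only a limit in this assay, so no step from bromo to fluoro can be read between them. The compounds shown leave open what this change does and which structure, if any, would give a measurable value in this assay.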